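The source may hold more compounds than are shown below. What is called first, only, known or untested is meant among the compounds shown, and "the series" means these compounds.

Compound 1, `COc1cc(/C=C/C(=O)c2cccc(-n3cc(-c4ccc(Cl)cc4)[nH]c3=O)c2)ccc1O`, gives 3180 nM in a functional assay on NCI-H23 cells (Homo sapiens) for inhibition; on this read-out higher numbers stand for weaker inhibition of growth and lower numbers for stronger inhibition of growth. Compound 2, `COc1ccc(-c2cn(-c3cccc(C(=O)/C=C/c4cc(OC)c(OC)c(OC)c4)c3)c(=O)[nH]2)cc1`, gives 1630 nM in this assay.

Compound 2 shows the lower of the two numbers, yet its gap to compound 1 lies within the scatter, so the two compounds cannot be told apart. Compound 3, `COc1ccc(-c2cn(-c3cccc(C(=O)/C=C/c4ccc(O)c(OC)c4)c3)c(=O)[nH]2)cc1`, differs from compound 2 in one place: 4-hydroxy-3-methoxyphenyl in place of 3,4,5-trimethoxyphenyl on a double-bonded chain carbon bound to a double-bonded chain carbon. Among the measured compounds shown here, no measured pair shows this change alone, so its size must be guessed. The step from compound 2 to compound 3 in this assay is expected to be small, if anything toward weaker inhibition of growth, a 1.5-fold higher number from compound 2 to compound 3 (0.19 log units; within the scatter). Compound 3 is therefore estimated at 2500 nM, with a range from 1000 nM to 6500 nM.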

Compound 3, concentration for 50% growth inhibition: 2850 nM
Compound 3: middle estimate off by 1.1-fold (0.06 log units), on the low side; measured number inside the range.
By their numbers in this assay, from the lowest: compounds 2, 3 and 1 (each within the scatter of the next).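

In this assay, 4-hydroxy-3-methoxyphenyl in place of 3,4,5-trimethoxyphenyl on a double-bonded chain carbon bound to a double-bonded chain carbon gives a 1.7-fold higher number from compound 2 to compound 3 (0.24 log units; within the scatter) and so leaves the read-out indistinguishable, even though the entering group brings a hydrogen-bond donor and fewer heavy atoms. Methoxy in place of chloro on an aromatic carbon gives a 1.1-fold lower number from compound 1 to compound 3 (0.05 log units; within the scatter) and is equally unresolved. Nothing available explains either step.

Going by these compounds, whether an amine or a carboxylic acid at either place would give a number beyond the scatter stays open.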